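Replacing a phenolic hydroxy with methyl in a lactone series

A few compounds are considered here, and "the series" means these few. Any claim that something is new, unique, unknown or untested is made for them only; others in the source may bear on it.

Measured compounds:
compound 1, `O=C1OC[C@H](Cc2ccccc2)[C@H]1Cc1ccccc1Cl`, 37000 nM
compound 2, `O=C1OC[C@H](Cc2ccccc2)[C@H]1Cc1ccc(O)cc1`, 88000 nM

Going by the values given here, in a functional assay on HL-60 cells (Homo sapiens) for cytotoxicity, read by WST assay, with a stated time of 48 h (on this read-out higher numbers stand for an effect only at larger amounts of compound and lower numbers for an effect already at smaller amounts), compound 2 stands at the highest of the two numbers so far; its nearest neighbour is compound 1, and the step of a 2.4-fold higher number from compound 1 to compound 2 (0.38 log units; beyond the scatter) is the only measured step in the set. Compound 3, `Cc1ccc(C[C@H]2C(=O)OC[C@@H]2Cc2ccccc2)cc1`, is not yet measured. It differs from compound 2 by methyl in place of hydroxy on an aromatic carbon. Among the compounds with values here, no measured step swaps these two groups at this place, so the single step from compound 1 to compound 2 bears on it only loosely: there the loss of a 4-hydroxyphenyl in favour of a 2-chlorophenyl went with a modest lower number. On that slender basis compound 3 is expected to give a modestly lower number in this assay, a 1.8-fold lower number from compound 2 to compound 3 (0.25 log units; within the scatter), though a result within the scatter would not surprise. The estimate for compound 3 is 50000 nM, with a range from 20000 nM to 120000 nM.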

Compound 3, half-maximal effective concentration: 44000 nM
For compound 3 the middle estimate is 1.1-fold (0.06 log units) above the measured one; the measured number falls inside the stated range.
By their numbers in this assay, from the lowest: compounds 1, 3 and 2 (each within the scatter of the next, the first and the last beyond it).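

In this assay, methyl in place of hydroxy on an aromatic carbon para to a large group gave a 2.0-fold lower number from compound 2 to compound 3 (0.30 log units; within the scatter) and so showed that, at this position, a group counted with one hydrogen-bond donor and one acceptor can give way to one counted with neither without a shift beyond the scatter. The comparison with the 2-chlorophenyl group gave a 1.2-fold higher number from compound 1 to compound 3 (0.08 log units; within the scatter) and so the gap beyond the scatter seen earlier does not reappear with 4-methylphenyl. No supporting data are available to explain these results.

From the compounds shown here alone, whether an amine, a methoxy group or a carboxylic acid at this place would stay within the scatter of hydroxy and methyl remains open. So does whether methyl would behave the same way on another carbon of this ring.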